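Para substituent on the aryl hydrazone: nitro to amino

The source may hold more compounds than are shown below. What is called first, only, known or untested is meant among the compounds shown, and "the series" means these compounds.

Going by the values given here, compound 2 `C/C(=N\Nc1nc2ccccc2nc1Cc1ccccc1)c1ccc([N+](=O)[O-])cc1` gives 680 nM in an assay on isolated protein for inhibition of Amine oxidase [flavin-containing] A (Homo sapiens), read by spectrophotometry (a higher number here means a weaker inhibitor, a lower number a stronger inhibitor), the highest of the two numbers so far; its nearest neighbour, compound 1 `COc1ccc(/C(C)=N/Nc2nc3ccccc3nc2Cc2ccccc2)cc1`, gives 89 nM. Among the compounds with values here, the only measured step, a 7.6-fold higher number from compound 1 to compound 2 (0.88 log units; beyond the scatter), is the one change that bears on the new compound. Compound 3 `C/C(=N\Nc1nc2ccccc2nc1Cc1ccccc1)c1ccc(N)cc1` differs from compound 2 by amino in place of nitro on an aromatic carbon. Within the data shown here, no measured step has amino entering, so the expectation rests on a 7.6-fold higher number from compound 1 to compound 2 (0.88 log units; beyond the scatter) being reversed in part: a lower number, beyond the scatter but less sure in size. For compound 3 the expected step is a 3.4-fold lower number from compound 2 to compound 3 (0.53 log units; beyond the scatter). Compound 3 is thus estimated at 200 nM, within 50 nM to 800 nM.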

Compound 3, half-maximal inhibitory concentration: 9.8 nM
Compound 3: the middle estimate sits 20-fold (1.31 log units) above what was measured; the whole stated range lies above it.
By their numbers in this assay, from the lowest: compound 3; then compound 1; then compound 2.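

In this assay, the substituent at this position on the aromatic ring moves the number further than the methoxy and nitro pair alone showed: amino in place of nitro gives a 69-fold lower number from compound 2 to compound 3 (1.84 log units; beyond the scatter) and amino in place of methoxy gives a 9.1-fold lower number from compound 1 to compound 3 (0.96 log units; beyond the scatter). Amino therefore gives the lowest number of the three groups, with methoxy in the middle and nitro highest. Nothing at hand accounts for this order. Still open, on these data alone, is whether a methylamino, dimethylamino or acetamide group at this position keeps the number of compound 3 , and whether a hydroxyl group does the same.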